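Acetyl to Dimethylamino: Expected Effect on Kidney Cancer Cells

The source may hold more compounds than are shown below. What is called first, only, known or untested is meant among the compounds shown, and "the series" means these compounds.

Measured compounds:
Compound 1, `COc1cc(C)cc(-c2c(-c3ccnc(-c4ccc(C(C)=O)cc4)c3)cnn2CC#N)c1`, gives 102%
Compound 2, `COc1cc(C)cc(-c2nn(CC#N)cc2-c2ccc(-c3cccc(C(C)=O)c3)nc2)c1`, gives 97%

Both compounds were tested in a functional assay on 786-0 cells (Homo sapiens) for cytotoxicity, read by sulforhodamine B assay, with a stated time of 48 h, tested at 0.001 uM; on this read-out higher numbers stand for a weaker effect at the one concentration tested and lower numbers for a stronger effect. In this assay compound 1 gives 102%, a number that means the cells grew essentially as untreated cells do at the single, very low concentration used. Compound 2 gives 97% in this assay, and the gap between compound 1 and compound 2 lies within the usual scatter of repeated measurements, so the two cannot be told apart on these numbers. Compound 1 therefore stands among numbers that all point to no measurable effect.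

Compound 3, `COc1cc(C)cc(-c2c(-c3ccnc(-c4ccc(N(C)C)cc4)c3)cnn2CC#N)c1`, differs from compound 1 in one place: dimethylamino in place of acetyl on an aromatic carbon. The shared core and the nitrile-bearing chain are untouched.

For the measured compounds named here, with only two measured compounds and no measured step between them, there is no basis for expecting a change of any direction, and the step of a number 3 percentage points lower from compound 1 to compound 3 (within the scatter) is expected to stay within the scatter. Compound 3 is estimated at 99% in this assay, within a range from 86% to 112%.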

Compound 3, a percentage reported as activity, at one concentration (the size of the read-out at that concentration, not a potency): 95%
Compound 3: middle estimate off by 4 percentage points, on the high side; the measured number falls inside the stated range.
By their numbers in this assay, from the lowest: compounds 3, 2 and 1 (each within the scatter of the next).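

For the compounds shown here, compound 1 and compound 3 form the first pair here that differs in only one place, so this change can be read directly: dimethylamino replaces acetyl on an aromatic carbon, para to a large group. In this assay, the comparison gives a number 7 percentage points lower from compound 1 to compound 3 (within the scatter), so the two groups cannot be told apart at this single, very low concentration, even though the swap exchanges the carbonyl of acetyl for the nitrogen of dimethylamino while keeping 3 heavy atoms. No independent measurement bears on this result, so the comparison can report only the read-out and offers no explanation for it.

A single concentration at which cells grow much as untreated cells do leaves open whether acetyl and dimethylamino would separate at a greater concentration, or whether either compound affects these cells at all. Going by these compounds, it also remains open whether a carboxylic acid, a primary amine or a longer carbon chain at this same position would give a reading distinct from those of compound 1 and compound 3.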